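From naphthalen-2-yl to thiophen-2-yl on the chain carbon

The source may hold more compounds than are shown below. What is called first, only, known or untested is meant among the compounds shown, and "the series" means these compounds.

Compound 1 `CC(=O)OC[C@H]1O[C@@H](n2cc(CN3C(=O)/C(=C\c4ccccc4)c4ccccc43)nn2)[C@H](OC(C)=O)[C@@H](OC(C)=O)[C@@H]1OC(C)=O` carries a phenyl group on the double-bonded chain carbon, and in a functional assay on HeLa cells (Homo sapiens) for cytotoxicity, read by sulforhodamine B assay, with a stated time of 48 h (on this read-out higher numbers stand for weaker inhibition and lower numbers for stronger inhibition), compound 1 gives 33300 nM. Compound 2 `CC(=O)OC[C@H]1O[C@@H](n2cc(CN3C(=O)/C(=C\c4ccc(N(C)C)cc4)c4ccccc43)nn2)[C@H](OC(C)=O)[C@@H](OC(C)=O)[C@@H]1OC(C)=O` gives 25000 nM, which amounts to a 1.3-fold lower number from compound 1 to compound 2 (0.12 log units; within the scatter). Compound 3 `CC(=O)OC[C@H]1O[C@@H](n2cc(CN3C(=O)/C(=C\c4ccc5ccccc5c4)c4ccccc43)nn2)[C@H](OC(C)=O)[C@@H](OC(C)=O)[C@@H]1OC(C)=O` is reported only as a limit of the assay, > 100000 nM. Compound 3 thus sits at the weak end of what is shown, with an at least 3.0-fold higher number from compound 1 to compound 3 (0.47 log units; beyond the scatter) and an at least 4.0-fold higher number from compound 2 to compound 3 (0.60 log units; beyond the scatter). Compound 4 `CC(=O)OC[C@H]1O[C@@H](n2cc(CN3C(=O)/C(=C\c4cccs4)c4ccccc43)nn2)[C@H](OC(C)=O)[C@@H](OC(C)=O)[C@@H]1OC(C)=O` differs from compound 3 by thiophen-2-yl in place of naphthalen-2-yl on a double-bonded chain carbon bound to a double-bonded ring carbon. Because the two-ring naphthalen-2-yl went with higher numbers than single-ring phenyl groups in an at least 3.0-fold higher number from compound 1 to compound 3 (0.47 log units; beyond the scatter), returning to one small aromatic ring is expected to bring the number down, about an at least 2.5-fold lower number from compound 3 to compound 4 (0.39 log units; beyond the scatter). Compound 4 is therefore estimated at 40000 nM, with a range from 15000 nM to 150000 nM.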

Compound 4, half-maximal inhibitory concentration: > 100000 nM
Compound 4: only a limit was reported (the forecaster's own chance of this, stated with the estimate: 35%); at least 2.5-fold (0.39 log units) between middle value and limit.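

Thiophen-2-yl on the double-bonded chain carbon shows that a single aromatic ring is not enough to stay with the phenyl groups: the result is an at least 3.0-fold higher number from compound 1 to compound 4 (0.47 log units; beyond the scatter) and an at least 4.0-fold higher number from compound 2 to compound 4 (0.60 log units; beyond the scatter). Among the compounds shown, the weak end is therefore not confined to the two-ring naphthalen-2-yl. The step between compound 3 and compound 4 cannot be read, because both stand at the same limit: the limit of > 100000 nM in this assay, at which 2 of the 4 values shown sit.

From the compounds shown here alone, it remains open whether a pyridine or furan ring on this carbon would stay with compound 1 and compound 2 or also reach the limit. Going by these compounds, how far compound 3 and compound 4 lie beyond that limit also remains open.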